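The compounds below may be only part of what the source reports. "The series", "measured", "known", "first", "only" and "open" are said of these compounds alone.

Compounds 1 and 2 share one core and differ only in where a single fluorine sits on an aromatic ring at the end of a chain. Compound 1 `O=c1[nH]/c(=N\OCCCc2cccc(F)c2)ccn1[C@@H]1O[C@H](COP(=O)(O)OP(=O)(O)OP(=O)(O)O)[C@@H](O)[C@H]1O` is the more potent of the pair: in a functional assay on 1321-N1 cells for agonist activity at P2Y purinoceptor 2 (Homo sapiens), read by scintillation counting and inositol phosphate accumulation (a lower number here means that less compound is needed, a higher number that more compound is needed for the effect), compound 1 gives 190 nM. Compound 2 `O=c1[nH]/c(=N\OCCCc2ccc(F)cc2)ccn1[C@@H]1O[C@H](COP(=O)(O)OP(=O)(O)OP(=O)(O)O)[C@@H](O)[C@H]1O` carries the fluorine on another ring carbon, and in this assay compound 2 gives 547 nM, the higher of the two numbers measured, with the step of a 2.9-fold higher number from compound 1 to compound 2 (0.46 log units; beyond the scatter) lying beyond the scatter. Compound 3 `C#CCCNC(=O)COc1ccc(CCCO/N=c2/ccn([C@@H]3O[C@H](COP(=O)(O)OP(=O)(O)OP(=O)(O)O)[C@@H](O)[C@H]3O)c(=O)[nH]2)cc1` keeps the core and chain of compound 2 but swaps the fluorine for a much larger group: a group of 9 heavy atoms (6 carbon, 1 nitrogen, 2 oxygen; no ring) in place of one fluorine atom, on an aromatic carbon. Within the data shown here, the only measured step, a 2.9-fold higher number from compound 1 to compound 2 (0.46 log units; beyond the scatter), concerns moving a fluorine, not exchanging it for a large group, so it offers little guidance on the size or direction of this change. The expectation is that compound 3 lands near compound 2, with wide uncertainty, a step of a 1.3-fold higher number from compound 2 to compound 3 (0.11 log units; within the scatter). Compound 3 is estimated at 700 nM, expected to fall between 200 nM and 3000 nM.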

Compound 3, half-maximal effective concentration: 109 nM
Compound 3: the middle estimate sits 6.4-fold (0.81 log units) above what was measured; the whole stated range lies above it.
By their numbers in this assay, from the lowest: compounds 3 and 1 (each within the scatter of the next); then compound 2.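

In this assay, among these compounds, replacing the single fluorine with the group of 9 heavy atoms gives a 5.0-fold lower number from compound 2 to compound 3 (0.70 log units; beyond the scatter), so less compound is needed for the effect even though the new group is far larger. The earlier pair showed only that moving a fluorine around the ring changes the number; this step shows that the ring carbon holding the fluorine in compound 2 can carry a long group with no ring, and that the number falls rather than rises. Nothing given here explains why the number falls in this one pair, and no measurement speaks to a cause.

Which part of the new group matters stays open, since it brings in an amide, an ether oxygen and a triple bond all at once, and a methoxy group, a carboxylic acid or an amine on the same ring carbon would help to separate these parts. As far as these compounds go, it is also open whether the same long group would give a similar number on the ring carbon that holds the fluorine in compound 1.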